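Compound 3: a step beyond a shared assay limit?

This account rests on a few compounds, and the source may have more. Where it says the series, first, only, none or still open, it means among the compounds named here.

Compound 1 `OC[C@H]1O[C@@H](n2cnc3c(NCc4ccccc4Br)ncnc32)[C@H](O)[C@@H]1O`: > 166000 nM
Compound 2 `OC[C@H]1O[C@@H](n2cnc3c(NCc4ccc(F)c(F)c4F)ncnc32)[C@H](O)[C@@H]1O`: > 166000 nM
Compound 3 `OC[C@H]1O[C@@H](n2cnc3c(NCc4cc(O)cc(O)c4)ncnc32)[C@H](O)[C@@H]1O`: not yet measured

The read-out here is a functional assay on G-361 cells (Homo sapiens) for antiproliferative activity, with a stated time of 72 h; on this read-out lower numbers stand for stronger inhibition and higher numbers for weaker inhibition. In this assay compound 2 gives > 166000 nM, which is a limit of the assay and not a number. Compound 1 gives > 166000 nM, which is likewise a limit. So compound 2 has no measured potency, and the evidence amounts to the limit of > 166000 nM in this assay, at which 2 of the 2 values shown sit. Within the data shown here, the only measured step is a step that the two limits leave unreadable from compound 1 to compound 2, and it gives no size to carry forward.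

The change now in question is 3,5-dihydroxyphenyl in place of 2,3,4-trifluorophenyl on a saturated chain carbon bound to a nitrogen on an aromatic ring. It puts 3,5-dihydroxyphenyl in place of 2,3,4-trifluorophenyl on a saturated chain carbon bound to a nitrogen on an aromatic ring, so hydrogen-bond donors and acceptors enter where there were none. With no readable step to draw on, the expectation in this assay is uncertain: compound 3 may stay at the limit, or it may show a modest move toward stronger inhibition. The estimated step is an at least 2.7-fold lower number from compound 2 to compound 3 (0.44 log units; beyond the scatter). For compound 3 the expected value is 60000 nM, with an estimated range of 5000 nM to 166000 nM.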

Compound 3, half-maximal inhibitory concentration: > 166000 nM
Compound 3: only a limit was reported; the forecaster's own chance of this, stated with the estimate: 50%; at least 2.7-fold (0.44 log units) between middle value and limit.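

In this assay compound 3 gives > 166000 nM, which is a limit of the assay and not a number. Among these compounds, no step can therefore be read between compound 1, compound 2 and compound 3. The compounds shown leave open whether any group in this place gives a measurable potency, as the result so far stands at this: the limit of > 166000 nM in this assay, at which 3 of the 3 values shown sit.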